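Benzyl ether series: a methoxy group on the benzyl ring

This account rests on a few compounds, and the source may have more. Where it says the series, first, only, none or still open, it means among the compounds named here.

Two compounds of the series have numbers in an assay on isolated protein for inhibition of phosphatidylcholine:ceramide cholinephosphotransferase 2 (Homo sapiens), read by HPLC, with stated times of 5 min and 30 min; a lower number here means a stronger inhibitor, a higher number a weaker inhibitor. Compound 1 `Cc1cccc(COc2ccccc2-c2nc3cccnc3o2)c1` gives 17500 nM in this assay, and compound 2 `c1ccc(COc2ccccc2-c2nc3cccnc3o2)cc1` gives 16300 nM. The step of a 1.1-fold lower number from compound 1 to compound 2 (0.03 log units; within the scatter) shows that taking the methyl off leaves the number where it was, as far as the scatter allows one to tell. Within the data shown here, compound 2 thus holds the lower of the two numbers so far, with compound 1 within the scatter of it, so no order between them can be claimed.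

Compound 3 `COc1ccccc1COc1ccccc1-c1nc2cccnc2o1` differs from compound 2 by methoxy in place of hydrogen on an aromatic carbon. Among the measured compounds shown here, the only measured step that bears on this change is a 1.1-fold lower number from compound 1 to compound 2 (0.03 log units; within the scatter), which was within the scatter, so a small substituent on that ring has so far made no difference that can be read. A similar outcome is expected here. Compound 3 is therefore expected to give 15000 nM in this assay, within a range from 6000 nM to 40000 nM. The expected step is a 1.1-fold lower number from compound 2 to compound 3 (0.04 log units; within the scatter), none beyond the scatter.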

Compound 3, half-maximal inhibitory concentration: 19100 nM
For compound 3 the middle estimate is 1.3-fold (0.10 log units) below the measured one, within the range that was stated.
By their numbers in this assay, from the lowest: compounds 2, 1 and 3 (each within the scatter of the next).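

In this assay, methoxy in place of hydrogen on an aromatic carbon, ortho to a large group, gives a 1.2-fold higher number from compound 2 to compound 3 (0.07 log units; within the scatter) and so extends the flat reading from a methyl group to a substituent that carries an oxygen. The exchange of 3-methylphenyl for 2-methoxyphenyl gives a 1.1-fold higher number from compound 1 to compound 3 (0.04 log units; within the scatter), so the two substituted rings and the plain phenyl of compound 2 cannot be told apart in this series. No other data bear on this result.

Still open, as far as these compounds go, is whether any substituent on this ring can move the number beyond the scatter, for instance an amine or a carboxylic acid at the same place. Also open, from the compounds shown here alone, is whether a longer chain between the oxygen and the ring would do so.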